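Aryl swap on the enone chain: toward compound 3

This account rests on a few compounds, and the source may have more. Where it says the series, first, only, none or still open, it means among the compounds named here.

compound 1 `O=C(/C=C\c1ccccc1O)N1N=C(c2ccncc2)OC1c1c[nH]c2ccccc12` — 26.8 ug/mL
compound 2 `O=C(/C=C\c1ccc(F)cc1)N1N=C(c2ccncc2)OC1c1c[nH]c2ccccc12` — > 30 ug/mL

In an ADME assay on HeLa cells (Homo sapiens) for cytotoxicity, read by MTT assay, with a stated time of 72 h (on this read-out higher numbers stand for weaker inhibition of growth and lower numbers for stronger inhibition of growth), compound 1 gives 26.8 ug/mL. Compound 2 reaches (the limit of > 30 ug/mL in this assay, at which 1 of the 2 values shown sits); its reading of > 30 ug/mL is a limit of the assay and not a number. For the measured compounds named here, the one measured step, an at least 1.1-fold higher number from compound 1 to compound 2 (0.04 log units; that floor lies within the scatter), is only a floor and sets no direction beyond the scatter; it shows merely that exchanging the aryl group did not move the number downward by a measurable amount.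

Compound 3 `O=C(/C=C\c1cccc(Br)c1)N1N=C(c2ccncc2)OC1c1c[nH]c2ccccc12` is the next member: 3-bromophenyl in place of 4-fluorophenyl on a double-bonded chain carbon bound to a double-bonded chain carbon. Going by the values given here, no measured step involves a 3-bromophenyl group, so the step just described is the only guide, and it suggests no shift beyond the scatter in this assay. Compound 3 is therefore expected to stay near the same limit, a number no higher from compound 2 to compound 3 (the limit leaves the size open). The estimate for compound 3 is 30 ug/mL, expected to fall between 15 ug/mL and 60 ug/mL, with a limit-only result about as likely as a number.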

Compound 3, concentration for 50% growth inhibition: > 30 ug/mL
Compound 3 gave a limit, no number (the forecaster's own chance of this, stated with the estimate: 55%); the middle value lies on the limit itself.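

In this assay compound 3 gives > 30 ug/mL, which is a limit of the assay and not a number. Placing 3-bromophenyl where compound 1 carries 2-hydroxyphenyl gives an at least 1.1-fold higher number from compound 1 to compound 3 (0.04 log units; that floor lies within the scatter), so a second replacement of 2-hydroxyphenyl on a double-bonded chain carbon bound to a double-bonded chain carbon, after 4-fluorophenyl, shows no direction beyond the scatter. The step between the 4-fluorophenyl and 3-bromophenyl members cannot be read, so these two cannot be ordered, and the series stands as follows: the limit of > 30 ug/mL in this assay, at which 2 of the 3 values shown sit.

Still open, going by these compounds, is whether an amine or a carboxylic acid on the phenyl ring at this place would give a reading clearly lower than those of this series. Also open, on these data alone, is whether the reading of compound 1 truly differs from those of the other two members by more than the scatter.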